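Swapping a Nitro Group for a Carboxy Group

The source may report more compounds than this note shows. Statements on the series, on what has been measured and on what is new or still open speak of the compounds shown alone.

Three compounds built on one shared core were tested in a functional assay on H157 cells (Homo sapiens) for antiproliferative activity, read by trypan blue exclusion; a higher number here means a weaker inhibitor, a lower number a stronger inhibitor. Compound 1 `COc1cc(OC)c(/C=C/S(=O)(=O)Cc2ccc(OC)c(OP(=O)(O)O)c2)c(OC)c1` gives 7 nM. Compound 2 `COc1cc(OC)c(/C=C/S(=O)(=O)Cc2cc(OC)c(OC)c(OC)c2)c(OC)c1` reaches only the limit of the assay, > 20000 nM, so it has no number of its own. Compound 3 `COc1cc(OC)c(/C=C/S(=O)(=O)Cc2ccc([N+](=O)[O-])cc2)c(OC)c1` gives 20000 nM, the higher of the two numbers measured; compound 1 sits far lower, and that gap lies well beyond the usual scatter. Compound 4 `COc1cc(OC)c(/C=C/S(=O)(=O)Cc2ccc(C(=O)O)cc2)c(OC)c1` has not yet been measured. It differs from compound 3 in one place: carboxy in place of nitro on an aromatic carbon. Within the data shown here, no measured pair shows a step of this kind, so little change beyond the scatter is expected from compound 3 to compound 4 in this assay. The step is estimated as a 1.3-fold lower number from compound 3 to compound 4 (0.12 log units; within the scatter). Compound 4 is therefore expected to give about 15000 nM, within a range from 3000 nM to 40000 nM.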

Compound 4, half-maximal inhibitory concentration: 17500 nM
The estimate for compound 4 lay 1.2-fold (0.07 log units) below the measured number; the range from low to high includes it.
By their numbers in this assay, from the lowest: compound 1; then compounds 4 and 3 (each within the scatter of the next).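

The step, a 1.1-fold lower number from compound 3 to compound 4 (0.06 log units; within the scatter) in this assay, shows that on this aromatic carbon, para to a large group, carboxy and nitro cannot be told apart. Carboxy brings a hydrogen-bond donor that nitro lacks, yet the number does not move beyond the scatter. Both values also sit close to the top of the measurable range, where compound 2 gives a limit rather than a number: the limit of > 20000 nM in this assay, at which 1 of the 4 values shown sits.

Going by these compounds, what an amine or an amide would give at this place stays open. So does whether any single group here can bring the number down far.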